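Methoxy on the benzyl ring of the amide series

This account rests on a few compounds, and the source may have more. Where it says the series, first, only, none or still open, it means among the compounds named here.

The series shares one core; compound 1 `O=C1C=CC(=O)C(c2cc(-c3ccc(C(=O)N4CCC(C(F)(F)F)CC4)s3)on2)=C1`, compound 2 `CN(Cc1ccccc1)C(=O)c1ccc(-c2cc(C3=CC(=O)C=CC3=O)no2)s1` and compound 3 `O=C1C=CC(=O)C(c2cc(-c3ccc(C(=O)N4CCCCC4)s3)on2)=C1` differ only at the amide end. In a functional assay on A549 cells (Homo sapiens) for cytotoxicity, read by XTT assay, with a stated time of 72 h (on this read-out higher numbers stand for weaker inhibition and lower numbers for stronger inhibition), compound 1 gives only the limit > 30000 nM. In this assay compound 2 likewise gives only the limit > 30000 nM. In this assay compound 3 also gives only the limit > 30000 nM. The steps a step that the two limits leave unreadable from compound 1 to compound 2, a step that the two limits leave unreadable from compound 1 to compound 3 and a step that the two limits leave unreadable from compound 2 to compound 3 therefore carry no readable size, as the limit of > 30000 nM in this assay, at which 3 of the 3 values shown sit, shows. Compound 4 `COc1ccc(CN(C)C(=O)c2ccc(-c3cc(C4=CC(=O)C=CC4=O)no3)s2)cc1` differs from compound 2 by methoxy in place of hydrogen on an aromatic carbon. Within the data shown here, no measured step bears readably on this change; every amide variant so far sits at the limit. Compound 4 is thus expected to sit at the limit as well, with an estimate of 40000 nM (range 15000 nM to 150000 nM), the expected step that the limit leaves unreadable from compound 2 to compound 4 being none beyond the scatter.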

Compound 4, half-maximal inhibitory concentration: > 30000 nM
Compound 4 gave a limit, no number (the forecaster's own chance of this, stated with the estimate: 80%); the middle value is on the limit's open side.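

In this assay compound 4 gives only a limit, > 30000 nM, so no step can be read from compound 2 to compound 4. The compounds shown leave open whether any change at the amide end gives a value off the limit in this assay.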